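The compounds below may be only part of what the source reports. "The series", "measured", "known", "first", "only" and "open" are said of these compounds alone.

Measured so far in a functional assay on PC-3 cells (Homo sapiens) for inhibition; on this read-out higher numbers stand for weaker inhibition and lower numbers for stronger inhibition: compound 1 `Cc1c(C(=O)N/N=C\c2ccccc2O)oc2cccc(O)c12` gives 8350 nM. Compound 3 `COc1ccccc1/C=N\NC(=O)c1oc2cccc(O)c2c1C` gives 32700 nM. Compound 2 `COc1cccc(/C=N\NC(=O)c2oc3cccc(O)c3c2C)c1` gives only a limit of the assay, >= 40000 nM.

Among the two numbers, compound 3 stands highest; compound 1 is nearest, separated by a 3.9-fold higher number from compound 1 to compound 3 (0.59 log units; beyond the scatter). Compound 4 `Cc1c(C(=O)N/N=C\c2ccc(O)cc2O)oc2cccc(O)c12` has not been measured. It differs from compound 3 as follows: 2,4-dihydroxyphenyl in place of 2-methoxyphenyl on a carbon with a double bond to nitrogen. The step of a 3.9-fold higher number from compound 1 to compound 3 (0.59 log units; beyond the scatter) bears on this change most directly, since the methyl on the oxygen is removed again, and an at least 4.7-fold higher number from compound 1 to compound 2 (0.68 log units; beyond the scatter) also shows that the pattern on this ring matters. Compound 4 is therefore expected to return toward compound 1, a 3.6-fold lower number from compound 3 to compound 4 (0.56 log units; beyond the scatter). The estimate for compound 4 is 9000 nM, in the range 3000 nM to 30000 nM.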

Compound 4, half-maximal inhibitory concentration: 14800 nM
The estimate for compound 4 lay 1.6-fold (0.22 log units) below the measured number; the range from low to high includes it.
By their numbers in this assay, from the lowest: compounds 1 and 4 (each within the scatter of the next); then compound 3. At a limit, above all of these: compound 2.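

In this assay, 2,4-dihydroxyphenyl on the carbon with a double bond to nitrogen recovers part of what 2-methoxyphenyl loses, a 2.2-fold lower number from compound 3 to compound 4 (0.34 log units; beyond the scatter). The step of an at least 2.7-fold lower number from compound 2 to compound 4 (0.43 log units; beyond the scatter) points the same way against 3-methoxyphenyl, but it starts from a limit for compound 2: the limit of >= 40000 nM in this assay, at which 1 of the 4 values shown sits. With hydroxy in place of hydrogen on an aromatic carbon, compounds 1 and 4 cannot be told apart, a 1.8-fold higher number from compound 1 to compound 4 (0.25 log units; within the scatter), so this ring accepts the added hydroxy without a readable effect.

On these data alone, it remains open how an amine or a carboxylic acid at this place would read. As far as these compounds go, it is also open whether any group here gives a number well under that of compound 1, 8350 nM.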